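Pentyl on Selenium Carried to a Smaller Core

A few compounds are considered here, and "the series" means these few. Any claim that something is new, unique, unknown or untested is made for them only; others in the source may bear on it.

Compound 3 `Nc1nc([SeH])nc2ccccc12` and compound 1 `CCCCC[Se]c1nc(NCc2ccc(SC)cc2)c2ccccc2n1` were tested in a functional assay on CCRF-CEM cells (Homo sapiens) for cytotoxicity, read by MTT assay, with a stated time of 72 h; on this read-out higher numbers stand for weaker inhibition of growth and lower numbers for stronger inhibition of growth. Compound 3 gives 52400 nM, and compound 1 gives 83900 nM. Compound 2 `CSc1ccc(CNc2nc([SeH])nc3ccccc23)cc1` reached only a limit of the assay, > 100000 nM. Its result is the limit of > 100000 nM in this assay, at which 1 of the 3 values shown sits. From compound 2 to compound 1 the change is pentyl in place of hydrogen on a selenium, and it made an at least 1.1-fold lower number from compound 2 to compound 1 (0.07 log units; that floor lies within the scatter). Compound 4 `CCCCC[Se]c1nc(N)c2ccccc2n1` carries the same change on the core of compound 3: pentyl in place of hydrogen on a selenium. How the core of compound 3 differs from the core of compound 2 is not broken down here. The change from compound 2 to compound 1 gave an at least 1.1-fold lower number from compound 2 to compound 1 (0.07 log units; that floor lies within the scatter). On that basis a step of similar, small size is expected, a 1.2-fold lower number from compound 3 to compound 4 (0.10 log units; within the scatter). Compound 4 is therefore estimated at 42000 nM, with a likely range from 15000 nM to 100000 nM.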

Compound 4, concentration for total growth inhibition: 68000 nM
The estimate for compound 4 lay 1.6-fold (0.21 log units) below the measured number, within the range that was stated.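

In this assay, pentyl in place of hydrogen on a selenium gave a 1.3-fold higher number from compound 3 to compound 4 (0.11 log units; within the scatter), so on this smaller core the change cannot be told apart from the usual variation between repeated measurements. Set beside the earlier step, the change can be compared across the two cores only in part: the same change on two cores in this assay, an at least 1.1-fold lower number (0.07 log units; that floor lies within the scatter) from compound 2 to compound 1 and a 1.3-fold higher number (0.11 log units; within the scatter) from compound 3 to compound 4; the limit leaves it open whether they differ Compound 2 gives only a limit of the assay, so the pair does not show whether the change acts alike on both cores or differently: the limit of > 100000 nM in this assay, at which 1 of the 4 values shown sits.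

Left open is whether a longer chain or a benzyl group on the selenium, in place of pentyl, would move the number beyond that variation. Also open, on these data alone, is whether pentyl on a sulfur, in place of the selenium, would give a similar number.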